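The compounds below may be only part of what the source reports. "The series", "measured", "known", "first", "only" and "open" are said of these compounds alone.

Measured in a functional assay on DU-145 cells (Homo sapiens) for inhibition, read by trypan blue exclusion, with a stated time of 72 h; a higher number here means a weaker inhibitor, a lower number a stronger inhibitor:
- compound 1 `Cn1c(=O)c(S(=O)(=O)c2ccc(F)cc2F)cc2cnc(Nc3ccc4[nH]c(C(=O)O)cc4c3)nc21`: 10000 nM
- compound 2 `Cn1c(=O)c(S(=O)(=O)c2ccccc2)cc2cnc(Nc3cnc4[nH]ccc4c3)nc21`: 1000 nM
- compound 3 `Cc1ccc(S(=O)(=O)c2cc3cnc(Nc4cnc5c(c4)CC(=O)N5)nc3n(C)c2=O)cc1`: 15000 nM

Compound 3 has the highest number of the three, but it lies within the scatter of compound 1. Only compound 2 is separated from it beyond the scatter. Compound 4 `Cc1ccc(S(=O)(=O)c2cc3cnc(Nc4cnc5[nH]ccc5c4)nc3n(C)c2=O)cc1` differs from compound 3 by a group of 9 heavy atoms (7 carbon, 2 nitrogen; one five-membered aromatic ring with 1 hetero atom, one six-membered aromatic ring with 1 hetero atom) in place of a group of 10 heavy atoms (7 carbon, 2 nitrogen, 1 oxygen; one five-membered non-aromatic ring with 1 hetero atom, one six-membered aromatic ring with 1 hetero atom), on a nitrogen on an aromatic ring. For the measured compounds named here, no measured pair isolates this change. Going by the values given here, compound 2, the only measured compound holding the entering group, gives 1000 nM, so a stronger inhibitor is expected in this assay. The expected change is a 10-fold lower number from compound 3 to compound 4 (1.00 log units; beyond the scatter). The estimate for compound 4 is 1500 nM, with an expected range of 500 nM to 5000 nM.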

Compound 4, half-maximal inhibitory concentration: 25000 nM
Compound 4: the middle estimate sits 17-fold (1.22 log units) below what was measured; measured number above the stated range.
By their numbers in this assay, from the lowest: compound 2; then compounds 1, 3 and 4 (each within the scatter of the next, the first and the last beyond it).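

In this assay, the exchange of groups on a nitrogen on an aromatic ring gives a 1.7-fold higher number from compound 3 to compound 4 (0.22 log units; within the scatter), so the entering group does not by itself separate these two compounds. The larger step lies elsewhere: methyl in place of hydrogen on an aromatic carbon gives a 25-fold higher number from compound 2 to compound 4 (1.40 log units; beyond the scatter), which shows that the number of compound 2 does not carry over to a compound holding the same entering group. No supporting data bear on the reason for this step.
Open, as far as these compounds go, is whether a chlorine or a methoxy group on that aromatic carbon gives a number like that of compound 2. Also open, from the compounds shown here alone, is whether hydrogen there would give a step of similar size with the leaving group in place.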